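From carbamoyl to bromo on a shared core

The compounds below may be only part of what the source reports. "The series", "measured", "known", "first", "only" and "open" are said of these compounds alone.

Values in a functional assay on SiHa cells (Homo sapiens) for antiproliferative activity, read by CCK-8 assay, with a stated time of 72 h; on this read-out lower numbers stand for stronger inhibition and higher numbers for weaker inhibition:
Compound 1, `COc1ccc(-c2cncnc2-c2cc(OC)c(OC)c(OC)c2)cc1F`: 3340 nM
Compound 2, `CCOc1ccc(-c2cncnc2-c2cc(OC)c(OC)c(OC)c2)cc1`: 640 nM
Compound 3, `COc1cc(-c2ncncc2-c2ccc(C(N)=O)cc2)cc(OC)c1OC`: > 100000 nM

Compound 3 gives no number in this assay, only a limit, > 100000 nM. It is the only one of the three measured compounds that sits at a limit, and both of the others give numbers well clear of it.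

Compound 4, `COc1cc(-c2ncncc2-c2ccc(Br)cc2)cc(OC)c1OC`, has bromo in place of carbamoyl on an aromatic carbon, para to a large group: bromo in place of carbamoyl on an aromatic carbon.

The closest measured change put carbamoyl in place of ethoxy at this same place, and it gave an at least 150-fold higher number from compound 2 to compound 3 (2.19 log units; beyond the scatter). Arriving at 4-carbamoylphenyl from 3-fluoro-4-methoxyphenyl gave an at least 29-fold higher number from compound 1 to compound 3 (1.47 log units; beyond the scatter). Between the two measured compounds without carbamoyl, the change was only modest: a 5.2-fold lower number from compound 1 to compound 2 (0.72 log units; beyond the scatter). Within the data shown here, no measured compound carries bromo, so the size of the step rests on what leaving carbamoyl did in those comparisons. On the evidence of an at least 150-fold higher number from compound 2 to compound 3 (2.19 log units; beyond the scatter), a large step to a lower number is expected in this assay.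

The expected change is an at least 66-fold lower number from compound 3 to compound 4 (1.82 log units; beyond the scatter). For compound 4 the estimated value is 1500 nM, with an expected range of 300 nM to 8000 nM.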

Compound 4, half-maximal inhibitory concentration: 2960 nM
For compound 4 the middle estimate is 2.0-fold (0.30 log units) below the measured one; measured number inside the range.
By their numbers in this assay, from the lowest: compound 2; then compounds 4 and 1 (each within the scatter of the next). At a limit, above all of these: compound 3.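

In this assay, the step of an at least 33-fold lower number from compound 3 to compound 4 (1.52 log units; beyond the scatter) shows that leaving carbamoyl for bromo at this position brings the compound back to a measurable number, so carbamoyl, not the shared core, goes with the limit among the compounds shown. Bromo does not match ethoxy here, a 4.6-fold higher number from compound 2 to compound 4 (0.67 log units; beyond the scatter), while 4-bromophenyl and 3-fluoro-4-methoxyphenyl cannot be told apart, a 1.1-fold lower number from compound 1 to compound 4 (0.05 log units; within the scatter). The true size of the step from carbamoyl to bromo stays unknown because compound 3 gives no number, only a limit: the limit of > 100000 nM in this assay, at which 1 of the 4 values shown sits.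

The compounds shown leave open whether an amine or a carboxylic acid at this position would fall near carbamoyl or near bromo, and whether a longer chain such as propoxy would carry on from ethoxy. They also leave open how a plain 4-methoxyphenyl would stand, so the part played by the fluoro in 3-fluoro-4-methoxyphenyl cannot be separated from that of the methoxy.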